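The compounds below may be only part of what the source reports. "The series", "measured", "known", "first", "only" and "open" are said of these compounds alone.

Compound 1 `Cc1ccc(-c2c(N)n[nH]c2C)cc1C` was run in an assay on Sf9 cells for inhibition of mitogen-activated protein kinase kinase kinase 14 (Homo sapiens), read by ADP-Glo, with a stated time of 60 min (on this read-out lower numbers stand for stronger inhibition and higher numbers for weaker inhibition), and gave only a limit, > 100000 nM, not a number. Compound 2 `CCC(=O)n1nc(C)c(-c2ccc(Cl)c(Cl)c2)c1N`, which carries an ethyl group on a carbonyl carbon attached to an aromatic nitrogen of the shared core, gives 27400 nM in this assay. Going by the values given here, of the two results in this assay, that of compound 2 is the only actual number; the other rests at the limit of > 100000 nM in this assay, at which 1 of the 2 values shown sits. Compound 3 `Cc1nn(C(=O)c2ccncc2)c(N)c1-c1ccc(Cl)c(Cl)c1` is not yet measured and differs from compound 2 in one place: pyridin-4-yl in place of ethyl on a carbonyl carbon. Among the compounds with values here, no measured pair shows what such a swap does, so the direction rests on expectation alone; a moderate gain is expected, with the step from compound 2 to compound 3 estimated at a 1.8-fold lower number from compound 2 to compound 3 (0.26 log units; within the scatter). Compound 3 is accordingly estimated at 15000 nM in this assay, with a likely range from 4000 nM to 60000 nM.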

Compound 3, half-maximal inhibitory concentration: 58200 nM
Compound 3: the middle estimate sits 3.9-fold (0.59 log units) below what was measured, and the stated range covers the measured number.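

The carbonyl carbon on the aromatic nitrogen now has its first measured swap: in this assay, pyridin-4-yl in place of ethyl gives a 2.1-fold higher number from compound 2 to compound 3 (0.33 log units; beyond the scatter), a modest step towards weaker inhibition. This place therefore still gives a measurable number with a six-membered aromatic ring on the carbonyl carbon, but that ring brings no gain over the ethyl group. Nothing measured here accounts for the step.

From the compounds shown here alone, with only these two groups compared at this place, it remains open whether the change follows the ring itself or its nitrogen, which a plain phenyl group could separate, and whether a methyl group or a longer chain such as butyl would differ from ethyl. Going by these compounds, whether the same swap would act alike on a differently substituted core is also open.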